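Series notes: alkoxy chain length on the shared core

The compounds below may be only part of what the source reports. "The series", "measured", "known", "first", "only" and "open" are said of these compounds alone.

Measured so far in a functional assay on aorta (strain Wistar) for inhibition, with Thoracic aorta (Rattus norvegicus) as the target; on this read-out lower numbers stand for stronger inhibition and higher numbers for weaker inhibition:
compound 1, `CCOc1nc(-c2cc3ccccc3o2)cc(-c2ccccc2)c1C#N`, 310000 nM
compound 2, `CCOc1nc(-c2cc3ccccc3o2)cc(-c2cccc3ccccc23)c1C#N`, 344000 nM
compound 3, `COc1nc(-c2cc3ccccc3o2)cc(-c2ccc(Cl)cc2)c1C#N`, 286000 nM

Compound 3 stands together with the other two: its gap to compound 1 and its gap to compound 2 both fall within the scatter, so no order among the three can be read from these numbers. Among the compounds with values here, the only single-point step measured, a 1.1-fold higher number from compound 1 to compound 2 (0.05 log units; within the scatter), is also within the scatter.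

Compound 4, `CCOc1nc(-c2cc3ccccc3o2)cc(-c2ccc(Cl)cc2)c1C#N`, has not yet been run in this assay. It differs from compound 3 by methyl in place of hydrogen on a saturated chain carbon bound to an oxygen on an aromatic ring; cut one bond further out, the change reads methyl to ethyl, methoxy to ethoxy. Within the data shown here, no measured pair isolates this change: compound 1 and compound 2 both carry the ethoxy already, and compound 3 is the only methoxy member, so the step from methoxy to ethoxy has no direct precedent here. What the three numbers do show is that the one aromatic replacement tried moved this assay by nothing beyond the scatter. Against that background the expectation for compound 4 is a step of a 1.0-fold higher number from compound 3 to compound 4 (0.02 log units; within the scatter), that is, no movement beyond the scatter. Compound 4 is therefore estimated at 300000 nM, with a range from 150000 nM to 600000 nM.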

Compound 4, half-maximal inhibitory concentration: 221000 nM
The estimate for compound 4 lay 1.4-fold (0.13 log units) above the measured number; the measured number falls inside the stated range.
By their numbers in this assay, from the lowest: compounds 4, 3, 1 and 2 (each within the scatter of the next).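

Within the data shown here, the first direct reading of methyl in place of hydrogen on a saturated chain carbon bound to an oxygen on an aromatic ring, methoxy to ethoxy, comes in this assay as a 1.3-fold lower number from compound 3 to compound 4 (0.11 log units; within the scatter) and shows no separation at this position on the 4-chlorophenyl compounds. With the ethoxy held fixed, chloro in place of hydrogen on an aromatic carbon reads as a 1.4-fold lower number from compound 1 to compound 4 (0.15 log units; within the scatter) and 4-chlorophenyl in place of naphthalen-1-yl reads as a 1.6-fold lower number from compound 2 to compound 4 (0.19 log units; within the scatter) and both stay within the scatter, so changes at the alkoxy chain and on the aromatic group alike leave these four compounds unresolved. No independent data bear on these readings.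

The compounds shown leave open whether a longer chain such as propoxy or butoxy, a branched isopropoxy, or a chain ending in an amine or a carboxylic acid at this position would give a step beyond the scatter. They also leave open whether methoxy to ethoxy reads the same with phenyl or naphthalen-1-yl in place of 4-chlorophenyl, and whether any change on the shared core separates from this group.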